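The source may hold more compounds than are shown below. What is called first, only, known or untested is meant among the compounds shown, and "the series" means these compounds.

Measured compounds:
compound 1, `Nc1cccc(Nc2nccc(-c3ccccn3)n2)c1`, 300 nM
compound 2, `CC(=O)Nc1cccc(Nc2nccc(-c3ccccn3)n2)c1`, 300 nM
compound 3, `Cc1cc(C)cc(Nc2nccc(-c3ccco3)n2)c1`, 700 nM

In a functional assay for inhibition, with Homo sapiens as the target (on this read-out lower numbers stand for stronger inhibition and higher numbers for weaker inhibition), compound 2 stands level with compound 1, the two together giving the lowest numbers of the three; compound 3 gives the higher number, 700 nM, and that gap lies beyond the scatter. Within the data shown here, the one step with a bearing on the new compound is no change at the digits printed from compound 1 to compound 2 (within the scatter), which shows that the substituent on that aromatic carbon can be extended without moving the number.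

Compound 4, `CCOC(=O)c1cccc(Nc2nccc(-c3ccccn3)n2)c1`, differs from compound 2 by ethoxycarbonyl in place of acetamido on an aromatic carbon. This is a larger change than the one already measured: the whole acetamido leaves, its hydrogen-bond donor with it, and an ethoxycarbonyl enters. Among the measured compounds shown here, the only precedent, from compound 1 to compound 2, was flat, so a small step is expected for compound 4, with some allowance for a weaker number since the donor is lost. The step expected from compound 2 to compound 4 is a 1.7-fold higher number from compound 2 to compound 4 (0.22 log units; within the scatter). Compound 4 is therefore estimated at 500 nM, within a range from 200 nM to 1500 nM.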

Compound 4, half-maximal inhibitory concentration: 3000 nM
The estimate for compound 4 lay 6.0-fold (0.78 log units) below the measured number, and the stated range ends below it.
By their numbers in this assay, from the lowest: compounds 1 and 2 (each within the scatter of the next); then compound 3; then compound 4.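

In this assay, this position on the six-membered aromatic ring of carbon only is not indifferent to its substituent: a 10-fold higher number from compound 2 to compound 4 (1.00 log units; beyond the scatter), and likewise a 10-fold higher number from compound 1 to compound 4 (1.00 log units; beyond the scatter), although amino and acetamido had shown no change at the digits printed from compound 1 to compound 2 (within the scatter). The flat first step therefore does not mean that any group is tolerated here. This change removes the acetamido hydrogen-bond donor, adds a hydrogen-bond acceptor and replaces the nitrogen link with a carbonyl-bearing ester, and no measurement explains the loss.

From the compounds shown here alone, it remains open which of these differences matters, since they all change together in this single step. A primary carboxamide, a carboxylic acid or a methyl ester at the same position on the shared core would help separate them.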